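Phenyl variations on the ring amine nitrogen: estimate for compound 4

This account rests on a few compounds, and the source may have more. Where it says the series, first, only, none or still open, it means among the compounds named here.

Going by the values given here, compound 3 `CCCn1c(=O)[nH]c2nc(-c3ccc(S(=O)(=O)N4CCN(c5ccc(Cl)cc5F)CC4)cc3)[nH]c2c1=O` gives 9% in an assay on CHO cells for displacement of a labelled ligand from adenosine receptor A1 (Homo sapiens), read by scintillation counting, with a stated time of 90 min, tested at 1 uM, in the presence of a further agent that is not named here (on this read-out higher numbers stand for more inhibition at the one concentration tested (going by the name of the read-out) and lower numbers for less inhibition), the second highest of the three numbers so far. Compound 1 `CCCn1c(=O)[nH]c2nc(-c3ccc(S(=O)(=O)N4CCN(c5cccc(Br)c5)CC4)cc3)[nH]c2c1=O` gives -1% and compound 2 `CCCn1c(=O)[nH]c2nc(-c3ccc(S(=O)(=O)N4CCN(c5ccccc5Cl)CC4)cc3)[nH]c2c1=O` gives 25%. The steps among the measured compounds are modest at best: a number 26 percentage points higher from compound 1 to compound 2 (beyond the scatter), a number 16 percentage points lower from compound 2 to compound 3 (beyond the scatter), and a number 10 percentage points higher from compound 1 to compound 3 (within the scatter). Compound 4 `CCCn1c(=O)[nH]c2nc(-c3ccc(S(=O)(=O)N4CCN(c5ccc(C)cc5)CC4)cc3)[nH]c2c1=O` carries 4-methylphenyl in place of 4-chloro-2-fluorophenyl on an amine nitrogen in a ring. Among the compounds with values here, no measured step exchanges a halogenated phenyl for a methyl-bearing phenyl, so the closest guide is the general size of the swaps seen, none of which moves the read-out far. A small change is therefore expected, a number 1 percentage points higher from compound 3 to compound 4 (within the scatter), likely within the scatter and in no firm direction. Compound 4 is estimated at 10%, with a range from -5% to 30%.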

Compound 4, a percentage reported as inhibition, at one concentration (the size of the read-out at that concentration, not a potency): 12%
Compound 4: middle estimate off by 2 percentage points, on the low side; the range from low to high includes it.
By their numbers in this assay, from the lowest: compounds 1, 3 and 4 (each within the scatter of the next, the first and the last beyond it); then compound 2.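

In this assay, the exchange of 4-chloro-2-fluorophenyl for 4-methylphenyl gives a number 3 percentage points higher from compound 3 to compound 4 (within the scatter) and so does not separate these two groups, although the halogens are gone. The same group does separate from the other two aryl groups, with a number 13 percentage points lower from compound 2 to compound 4 (beyond the scatter) and a number 13 percentage points higher from compound 1 to compound 4 (beyond the scatter) as the steps. Nothing shown accounts for these steps.

Whether a methoxy group or a carboxylic acid on the phenyl ring would take the read-out clearly beyond the range of these compounds remains open. So does the outcome of replacing the phenyl ring with a benzyl group.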